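The compounds below may be only part of what the source reports. "The series", "measured", "known", "first", "only" and "open" are said of these compounds alone.

In a functional assay on cells (Homo sapiens) for antiproliferative activity, read by sulforhodamine B assay, with a stated time of 48 h (a higher number here means a weaker inhibitor, a lower number a stronger inhibitor), compound 1 (`CCCCCCCCCCCCCCNC(=O)[C@@H]1CSC(c2ccc(NC(C)=O)cc2)N1`) gives 2300 nM, compound 2 (`CCCCCCCCCCCCCCCNC(=O)[C@@H]1CSC(c2ccc(NC(C)=O)cc2)N1`) gives 1600 nM and compound 3 (`CCCCCCCCCCCCCCCCCNC(=O)[C@@H]1CSC(c2ccc(NC(C)=O)cc2)N1`) gives 8500 nM, the highest number of the three and so the weakest inhibitor among them. Compound 4 (`CCCCCCCCCCCCCCCCCCNC(=O)[C@@H]1CSC(c2ccc(NC(C)=O)cc2)N1`) lengthens the chain of compound 3, with this difference: methyl in place of hydrogen on a saturated chain carbon, ten or more bonds along the chain from an amide-type nitrogen. The measured steps of the same kind are a 1.4-fold lower number from compound 1 to compound 2 (0.16 log units; within the scatter), then a 3.7-fold higher number from compound 1 to compound 3 (0.57 log units; beyond the scatter) and a 5.3-fold higher number from compound 2 to compound 3 (0.73 log units; beyond the scatter). Compound 2 therefore goes against any steady rise with chain length, but the two steps to compound 3 both point upward. A small further rise is expected in this assay, and the estimated step is a 1.3-fold higher number from compound 3 to compound 4 (0.11 log units; within the scatter). For compound 4 the expected value is 11000 nM, with an estimated range from 4500 nM to 30000 nM.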

Compound 4, half-maximal inhibitory concentration: 22300 nM
Beside the measured number, compound 4's estimate is 2.0-fold (0.31 log units) below it; measured number inside the range.
By their numbers in this assay, from the lowest: compounds 2 and 1 (each within the scatter of the next); then compound 3; then compound 4.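

In this assay, methyl in place of hydrogen at this far chain carbon now gives a 2.6-fold higher number from compound 3 to compound 4 (0.42 log units; beyond the scatter), so the same change does not act alike on every chain length: the same change on two cores in this assay, a 1.4-fold lower number (0.16 log units; within the scatter) from compound 1 to compound 2 and a 2.6-fold higher number (0.42 log units; beyond the scatter) from compound 3 to compound 4, 3.8-fold (0.58 log units) apart, beyond the scatter of two such steps. Larger additions at this place give a 14-fold higher number from compound 2 to compound 4 (1.14 log units; beyond the scatter) and a 9.7-fold higher number from compound 1 to compound 4 (0.99 log units; beyond the scatter), which leaves compound 4 the weakest inhibitor of the four. Compound 2 goes against a steady rise with chain length, and the size of a step differs with its starting chain: the same change on two cores in this assay, a 3.7-fold higher number (0.57 log units; beyond the scatter) from compound 1 to compound 3 and a 14-fold higher number (1.14 log units; beyond the scatter) from compound 2 to compound 4, 3.8-fold (0.58 log units) apart, beyond the scatter of two such steps. The compounds shown leave open whether a longer chain would raise the number further, and whether a terminal amine or carboxylic acid on the chain would change this trend.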